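Compound 4: a dimethylpiperidine on a longer chain

A few compounds are considered here, and "the series" means these few. Any claim that something is new, unique, unknown or untested is made for them only; others in the source may bear on it.

Values measured in an ADME assay on microsomes from liver (Rattus norvegicus) for metabolic stability, read by LC-MS, using NADPH, at 37 degrees C; a higher number here means that the compound lasts longer, a lower number that the compound disappears faster:
- Compound 1 `Cc1ccccc1-c1nc(CN2CCC(C(=O)NCCCN3CCCCC3)CC2)c(C)o1`: > 0.5 h (a limit, not a number)
- Compound 2 `Cc1oc(-c2c(F)cccc2F)nc1CN1CCC(C(=O)NCCCN2C[C@H](C)C[C@H](C)C2)CC1`: 0.35 h
- Compound 3 `Cc1oc(-c2c(Br)cccc2Br)nc1CN1CCC(C(=O)NCCCN2C[C@H](C)C[C@H](C)C2)CC1`: 0.035 h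

Compound 1 stands at the limit of > 0.5 h in this assay, at which 1 of the 3 values shown sits. Compound 4 `Cc1ccccc1-c1nc(CN2CCC(C(=O)NCCCCN3C[C@H](C)C[C@H](C)C3)CC2)c(C)o1` has not yet been measured. Its structure departs from that of compound 1 in one place: (3,5-dimethylpiperidin-1-yl)methyl in place of piperidin-1-yl on a saturated chain carbon, three bonds along the chain from an amide-type nitrogen. Cut one bond further out, the same difference reads 2-(piperidin-1-yl)ethyl to 3-(3,5-dimethylpiperidin-1-yl)propyl.

Among the compounds with values here, no measured step covers this change. The only one, a 10-fold lower number from compound 2 to compound 3 (1.00 log units; beyond the scatter), lies elsewhere in the molecule, so it bears on the change only indirectly. It does show that a single exchange in this small set can move the half-life well beyond the scatter. Compound 2 and compound 3 both carry the 3,5-dimethylpiperidin-1-yl group, but they also differ from compound 1 in other ways, so they offer only a loose guide. Of these two, the estimate leans on compound 2 at 0.35 h.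

A lower number is therefore expected in this assay, with an estimated at least 2.0-fold lower number from compound 1 to compound 4 (0.30 log units; that floor lies within the scatter). Compound 4 is expected at 0.25 h, with an estimated range from 0.08 h to 0.6 h.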

Compound 4, half-life: 0.2 h
Compound 4: middle estimate off by 1.3-fold (0.10 log units), on the high side; low and high end bracket the measured number.
By their numbers in this assay, from the lowest: compound 3; then compounds 4 and 2 (each within the scatter of the next). At a limit, above all of these: compound 1.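

At the saturated chain carbon three bonds along the chain from an amide-type nitrogen, (3,5-dimethylpiperidin-1-yl)methyl in place of piperidin-1-yl gives, in this assay, an at least 2.5-fold lower number from compound 1 to compound 4 (0.39 log units; beyond the scatter). Within the data shown here, the one earlier step concerned only 2,6-dibromophenyl in place of 2,6-difluorophenyl on an aromatic carbon, so this is the first sign that a change at this end of the side chain can also move the half-life beyond the scatter. The step gives only a floor and not a full size, because compound 1 stands at a limit and not at a number: the limit of > 0.5 h in this assay, at which 1 of the 4 values shown sits.

The change joins a longer chain with two added methyl groups on the piperidine ring, and the compounds shown leave open which of the two goes with the lower half-life. On the core of compound 1, a 4-(piperidin-1-yl)butyl group and a 3-(3,5-dimethylpiperidin-1-yl)propyl group would pull the two apart, while the effect of a morpholine in place of the piperidine also remains an open question.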